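The source may hold more compounds than are shown below. What is called first, only, known or untested is meant among the compounds shown, and "the series" means these compounds.

Measured so far in a functional assay on A-431 cells (Homo sapiens) for cytotoxicity, read by MTT assay, with a stated time of 72 h; on this read-out higher numbers stand for weaker inhibition and lower numbers for stronger inhibition:
compound 1 `Cc1ccnc(/C(N)=N/NC(=S)N2CCSCC2)c1` gives 7200 nM
compound 2 `N/C(=N\NC(=S)N1CCSCC1)c1ccccn1` gives 6700 nM
compound 3 `N/C(=N\NC(=S)N1CCCCC1)c1ccccn1` gives 6900 nM

Compound 1 gives the highest of the three numbers, but the series is flat: the values of compound 1 and compound 3 sit within the scatter of each other, and the step of a 1.1-fold lower number from compound 1 to compound 2 (0.03 log units; within the scatter) is likewise within the scatter. Within the data shown here, the only change made at the thiocarbonyl carbon, a 1.0-fold higher number from compound 2 to compound 3 (0.01 log units; within the scatter), also stayed within the scatter.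

Compound 4 `Cc1ccnc(/C(N)=N/NC(=S)N2CCCC2)c1` is not yet measured. It differs from compound 1 by pyrrolidin-1-yl in place of thiomorpholin-4-yl on a thiocarbonyl carbon. The step that bears on it is a 1.0-fold higher number from compound 2 to compound 3 (0.01 log units; within the scatter), where a six-membered ring with one hetero atom replaced the thiomorpholin-4-yl on the same thiocarbonyl carbon without a change beyond the scatter. On that basis no step beyond the scatter is expected in this assay for the present exchange either, in neither direction, giving an expected 1.0-fold lower number from compound 1 to compound 4 (0.01 log units; within the scatter). Compound 4 is therefore estimated at 7000 nM in this assay, with a range from 3500 nM to 14000 nM.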

Compound 4, half-maximal inhibitory concentration: 900 nM
Beside the measured number, compound 4's estimate is 7.8-fold (0.89 log units) above it, outside the stated range (below it).
By their numbers in this assay, from the lowest: compound 4; then compounds 2, 3 and 1 (each within the scatter of the next).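

In this assay, the thiocarbonyl carbon turns out to be a place where the ring can matter: pyrrolidin-1-yl in place of thiomorpholin-4-yl gives an 8.0-fold lower number from compound 1 to compound 4 (0.90 log units; beyond the scatter), the only step shown that lies beyond the scatter. The other exchange at this carbon, piperidin-1-yl in place of thiomorpholin-4-yl, gave a 1.0-fold higher number from compound 2 to compound 3 (0.01 log units; within the scatter), so the flat picture from compound 1, compound 2 and compound 3 does not hold for every ring here, and losing the ring sulfur does not by itself go with a large step, as compound 3 also lacks it. No measured evidence on the series accounts for the step to compound 4.

Going by these compounds, it remains open whether the step persists with hydrogen in place of methyl on the aromatic carbon, since the piperidin-1-yl exchange was read without that methyl. On these data alone, it is also open whether the step follows ring size or belongs to pyrrolidin-1-yl alone, a question that azetidin-1-yl, azepan-1-yl or an open-chain dimethylamino group on the thiocarbonyl carbon would address.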